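The compounds below may be only part of what the source reports. "The series", "measured", "known", "first", "only" and "open" are said of these compounds alone.

In an ADME assay on microsomes from liver (Homo sapiens) for metabolic stability, with a stated time of 30 min, tested at 1 uM (a higher number here means that more of the compound is left, a lower number that less of the compound is left), compound 2 `CC[C@@H]1C(=O)N(C)c2cnc(-n3ccnc3-c3ccc(F)cc3)nc2N1[C@H]1CCOC1` gives 58% and sits level, within the scatter, with compound 1 `CC[C@@H]1C(=O)N(C)c2cnc(-c3cn[nH]c3-c3ccc(F)cc3F)nc2N1c1cnn(C)c1` at 48% and well clear of compound 3 `CC[C@@H]1C(=O)N(C)c2cnc(-n3ccnc3-c3ccc(F)cc3)nc2N1CCC(F)(F)F` at 27% in this small set. Compound 4 `CC[C@@H]1C(=O)N(C)c2cnc(-n3ccnc3-c3ccccc3)nc2N1[C@H]1CCOC1` has no number yet. It differs from compound 2 by a single swap, (hydrogen in place of fluoro on an aromatic carbon), hydrogen in place of fluoro on an aromatic carbon, which turns 4-fluorophenyl into phenyl. Going by the values given here, the only measured step that starts from compound 2, a number 31 percentage points lower from compound 2 to compound 3 (beyond the scatter), was large, but it replaces oxolan-3-yl with 3,3,3-trifluoropropyl, a different change in a different part of the molecule, so it offers only a sense of how far this read-out can move. Among the compounds with values here, no measured pair shows fluoro giving way to hydrogen. A small step within the scatter is therefore expected in this assay, with only a slight lean towards a lower number. The estimated step is a number 5 percentage points lower from compound 2 to compound 4 (within the scatter) in size. Compound 4 is estimated at 53% with an expected range from 36% to 68% for repeated measurements.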

Compound 4, percent of the compound remaining: 17%
Compound 4: middle estimate off by 36 percentage points, on the high side; measured number outside the range, below it.
By their numbers in this assay, from the lowest: compounds 4 and 3 (each within the scatter of the next); then compounds 1 and 2 (each within the scatter of the next).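

On the six-membered aromatic ring of carbon only, para to a large group, swapping a single fluoro for hydrogen gives a number 41 percentage points lower from compound 2 to compound 4 (beyond the scatter) in this assay and so marks this place as highly sensitive. Until now, the only large step shown, a number 31 percentage points lower from compound 2 to compound 3 (beyond the scatter), replaced oxolan-3-yl with 3,3,3-trifluoropropyl, a change of a whole group elsewhere in the molecule, whereas here the loss of one fluorine atom is enough for a large step. Nothing shown here explains why this swap lowers the number.

Going by these compounds, whether chloro, methoxy or a nitrile at this place would keep the number near that of compound 2 remains open. On these data alone, it is also open whether the fluoro carries the same weight when 3,3,3-trifluoropropyl stands in place of oxolan-3-yl.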